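This account rests on a few compounds, and the source may have more. Where it says the series, first, only, none or still open, it means among the compounds named here.

Values measured in a functional assay on MDA-MB-231 cells (Homo sapiens) for antiproliferative activity, read by MTT assay, with a stated time of 72 h (on this read-out lower numbers stand for stronger inhibition and higher numbers for weaker inhibition), are:

- compound 1 `CC1=CC[C@H]2[C@H](CC[C@]2(C)O)C(C)(C)[C@@H]1CC[C@H]1[C@]2(C)CC[C@H](OC(=O)c3ccc(Cl)cc3)C(C)(C)O[C@H]2CC[C@@]1(C)O` gives 10300 nM
- compound 2 `CC1=CC[C@H]2[C@H](CC[C@]2(C)O)C(C)(C)[C@@H]1CC[C@H]1[C@]2(C)CC[C@H](OC(=O)NS(=O)(=O)c3ccc(C)cc3)C(C)(C)O[C@H]2CC[C@@]1(C)O` gives 47100 nM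
- compound 3 `CC1=CC[C@H]2[C@H](CC[C@]2(C)O)C(C)(C)[C@@H]1CC[C@H]1[C@]2(C)CC[C@H](OC(=O)c3ccc(C(F)(F)F)cc3)C(C)(C)O[C@H]2CC[C@@]1(C)O` gives 19500 nM

On these numbers compound 3 sits together with compound 1. The measured step is a 1.9-fold higher number from compound 1 to compound 3 (0.28 log units; within the scatter) and so sets no order between the two. The third compound stands apart, as both a 2.4-fold lower number from compound 2 to compound 3 (0.38 log units; beyond the scatter) and a 4.6-fold higher number from compound 1 to compound 2 (0.66 log units; beyond the scatter) show.

Compound 4 `CC1=CC[C@H]2[C@H](CC[C@]2(C)O)C(C)(C)[C@@H]1CC[C@H]1[C@]2(C)CC[C@H](OC(=O)c3cccc(C(F)(F)F)c3)C(C)(C)O[C@H]2CC[C@@]1(C)O` differs from compound 3 in a single group on a carbonyl carbon, where the trifluoromethyl group sits at a different ring position: 3-(trifluoromethyl)phenyl in place of 4-(trifluoromethyl)phenyl on a carbonyl carbon is the whole change.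

Among the compounds with values here, no measured step moves a group around the ring, so none matches this change directly. The closest is the swap of chloro for trifluoromethyl on an aromatic carbon, a 1.9-fold higher number from compound 1 to compound 3 (0.28 log units; within the scatter) again, which stayed within the scatter. The two larger steps replace an entire group with ((4-methylphenyl)sulfonyl)amino or remove it, which is a much bigger change than this one.

A shift beyond the scatter is therefore not expected, and neither direction is favoured. The expected step is a 1.1-fold lower number from compound 3 to compound 4 (0.03 log units; within the scatter) in this assay on this estimate. The estimated value for compound 4 is 18000 nM with an expected range running from 9000 nM to 38000 nM around it.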

Compound 4, half-maximal inhibitory concentration: 36300 nM
Beside the measured number, compound 4's estimate is 2.0-fold (0.30 log units) below it, within the range that was stated.
By their numbers in this assay, from the lowest: compounds 1, 3, 4 and 2 (each within the scatter of the next, the first and the last beyond it).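

Moving the trifluoromethyl group, with 3-(trifluoromethyl)phenyl in place of 4-(trifluoromethyl)phenyl on the carbonyl carbon, gives a 1.9-fold higher number from compound 3 to compound 4 (0.27 log units; within the scatter) in this assay, so this first change of ring position sets no order between the two compounds. The move does alter how the pair relates to the other two compounds: the step of a 2.4-fold lower number from compound 2 to compound 3 (0.38 log units; beyond the scatter) separated the 4-(trifluoromethyl)phenyl compound from the ((4-methylphenyl)sulfonyl)amino compound, whereas a 1.3-fold lower number from compound 2 to compound 4 (0.11 log units; within the scatter) no longer does so for the 3-(trifluoromethyl)phenyl compound. In the same way, the step of a 1.9-fold higher number from compound 1 to compound 3 (0.28 log units; within the scatter) left the 4-chlorophenyl compound and the 4-(trifluoromethyl)phenyl compound unresolved, while a 3.5-fold higher number from compound 1 to compound 4 (0.55 log units; beyond the scatter) clearly places the 3-(trifluoromethyl)phenyl compound on the weaker side of the 4-chlorophenyl compound, though only modestly.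

Nothing in the available data explains these differences. The compounds shown also leave open how this ring would respond to a nitrile, a methoxy group or an amine in place of trifluoromethyl or chloro, and whether any such group would move the number far beyond the narrow band seen so far.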